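The source may report more compounds than this note shows. Statements on the series, on what has been measured and on what is new or still open speak of the compounds shown alone.

In an ADME assay on microsomes from liver (Rattus norvegicus) for metabolic stability, using NADPH, with a stated time of 10 min (on this read-out higher numbers stand for a more stable compound and lower numbers for a less stable compound), three compounds sharing one core have been measured. Compound 1 `NCCCCN(C[C@H]1Cc2ncccc2CN1)[C@H]1CCCc2cccnc21` carries a 3-aminopropyl group and gives 64%. Compound 2 `NC/C=C\CN(C[C@H]1Cc2ncccc2CN1)[C@H]1CCCc2cccnc21` has 3-aminoprop-1-en-1-yl in its place and gives 11%. Compound 3 `NC(=O)NCCCCN(C[C@H]1Cc2ncccc2CN1)[C@H]1CCCc2cccnc21` has 3-ureidopropyl there and gives 1%. Set against the other two, the data show a number 10 percentage points lower from compound 2 to compound 3 (within the scatter) and a number 63 percentage points lower from compound 1 to compound 3 (beyond the scatter).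

Compound 4 `CCN(CC)CCCCN(C[C@H]1Cc2ncccc2CN1)[C@H]1CCCc2cccnc21` has not yet been measured. Its difference is diethylamino in place of ureido on a saturated chain carbon, four bonds along the chain from an amine nitrogen, with diethylamino in place of ureido on a saturated chain carbon, four bonds along the chain from an amine nitrogen. For the measured compounds named here, no measured step introduces diethylamino. The closest guide is the change of carbamoyl in place of hydrogen on an amine nitrogen, a number 63 percentage points lower from compound 1 to compound 3 (beyond the scatter), which shows that this end of the chain can shift the number greatly. Retaining an amine does not secure a high number, however, as a number 53 percentage points lower from compound 1 to compound 2 (beyond the scatter) shows. With compound 3 at 1%, little room remains for a fall, so a rise is the likelier direction, though its size is poorly defined. The expected change is a number 19 percentage points higher from compound 3 to compound 4 (beyond the scatter), a moderate step upward. Compound 4 is estimated at 20%, with an expected range from 3% to 50%.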

Compound 4, percent of the compound remaining: 6%
The estimate for compound 4 lay 14 percentage points above the measured number; the measured number falls inside the stated range.
By their numbers in this assay, from the lowest: compounds 3, 4 and 2 (each within the scatter of the next); then compound 1.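

Carrying the change at the chain end further, swapping the terminal amino group for diethylamino gives a number 58 percentage points lower from compound 1 to compound 4 (beyond the scatter) in this assay, so the high number of compound 1 does not extend to this substituted amine. Diethylamino in place of ureido gives a number 5 percentage points higher from compound 3 to compound 4 (within the scatter) and 3-(diethylamino)propyl in place of 3-aminoprop-1-en-1-yl gives a number 5 percentage points lower from compound 2 to compound 4 (within the scatter), so three different changes to the 3-aminopropyl group of compound 1 now end at numbers that this read-out does not separate, and the earlier fall with ureido is no longer the only case of a large fall on a saturated chain. Nothing available gives a reason for this result.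

The compounds shown leave open whether a smaller change at the same nitrogen, such as methylamino or dimethylamino, would keep the number of compound 1 or already lose it. They also leave open how a ring amine such as piperidine or morpholine at the chain end, or a longer saturated chain ending in amino, would read in this assay.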